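The compounds below may be only part of what the source reports. "The series", "measured", "known", "first", "only" and "open" are said of these compounds alone.

Among the measured compounds shown here, compound 3 `O=C(CSc1nnc(-c2ccncc2)o1)N/N=C/c1ccccc1O` gives 4750 nM in a functional assay on MCF7 cells (Homo sapiens) for cytotoxicity, read by MTT assay, with a stated time of 48 h (a higher number here means a weaker inhibitor, a lower number a stronger inhibitor), the lowest of the three numbers measured so far. Compound 1 `O=C(CSc1nnc(-c2ccncc2)o1)N/N=C/c1ccccc1` gives 14600 nM in this assay, and compound 2 `COc1cccc(/C=N/NC(=O)CSc2nnc(-c3ccncc3)o2)c1` gives 13800 nM. The change to compound 4 `O=C(CSc1nnc(-c2ccncc2)o1)N/N=C/c1ccc(O)c(O)c1` is 3,4-dihydroxyphenyl in place of 2-hydroxyphenyl on a carbon with a double bond to nitrogen. For the measured compounds named here, two measured steps bear on it: a 3.1-fold lower number from compound 1 to compound 3 (0.49 log units; beyond the scatter) and a 2.9-fold lower number from compound 2 to compound 3 (0.46 log units; beyond the scatter), whereas a 1.1-fold lower number from compound 1 to compound 2 (0.02 log units; within the scatter). Going by the values given here, a single hydroxy thus helped once, but the hydroxy that leaves here belongs to the 2-hydroxyphenyl and the two that enter belong to the 3,4-dihydroxyphenyl, so no measured step covers this swap directly. A step of uncertain direction, most likely within the scatter or a modest weakening, is therefore expected, a 1.4-fold higher number from compound 3 to compound 4 (0.14 log units; within the scatter). Compound 4 is expected to give about 6500 nM, between 2000 nM and 20000 nM.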

Compound 4, half-maximal inhibitory concentration: 910 nM
Compound 4: middle estimate off by 7.1-fold (0.85 log units), on the high side; the whole stated range lies above it.
By their numbers in this assay, from the lowest: compound 4; then compound 3; then compounds 2 and 1 (each within the scatter of the next).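

Among the compounds shown here, on the carbon with a double bond to nitrogen, the choice of aromatic group can matter far more than the earlier compounds showed. 3,4-Dihydroxyphenyl gives a 5.2-fold lower number from compound 3 to compound 4 (0.72 log units; beyond the scatter) in place of 2-hydroxyphenyl, a 15-fold lower number from compound 2 to compound 4 (1.18 log units; beyond the scatter) in place of 3-methoxyphenyl, and a 16-fold lower number from compound 1 to compound 4 (1.21 log units; beyond the scatter) in place of phenyl. No measurement at hand explains this gain. Open, on these data alone, is whether a lone 4-hydroxyphenyl would match 3,4-dihydroxyphenyl, and whether an amine or a carboxylic acid on the ring could stand in for the hydroxy groups.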